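Swapping the Five-Membered Ring for a Pyridine

The source may hold more compounds than are shown below. What is called first, only, known or untested is meant among the compounds shown, and "the series" means these compounds.

Measured so far:
compound 2 `CCC(C)(C)Cc1c[nH]c(CCc2ccc(-n3cncn3)cc2)n1` gives 12 nM
compound 1 `CCC(C)(C)Cc1c[nH]c(CCc2ccc(-n3ncnn3)cc2)n1` gives 25 nM

Of the compounds shown here, two sharing the same core have been tested in a functional assay on HEK293 cells for agonist activity at Bombesin receptor subtype-3 (Mus musculus), read by luminescence and calcium flux, with a stated time of 10 min; on this read-out lower numbers stand for an effect already at smaller amounts and higher numbers for an effect only at larger amounts of compound. Compound 2 `CCC(C)(C)Cc1c[nH]c(CCc2ccc(-n3cncn3)cc2)n1` gives 12 nM, the lowest number of the two. Its nearest neighbour is compound 1 `CCC(C)(C)Cc1c[nH]c(CCc2ccc(-n3ncnn3)cc2)n1`, which gives 25 nM. For the measured compounds named here, the one measured step, a 2.1-fold lower number from compound 1 to compound 2 (0.32 log units; beyond the scatter), shows that exchanging one small five-membered ring for another moved the number only modestly.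

Compound 3 `CCC(C)(C)Cc1c[nH]c(CCc2ccc(-c3cccnc3)cc2)n1` differs from compound 2 in one place: pyridin-3-yl in place of 1H-1,2,4-triazol-1-yl on an aromatic carbon. Going by the values given here, no measured step covers a change from a five-membered ring to a six-membered one, so the only guidance is that the single measured step, a 2.1-fold lower number from compound 1 to compound 2 (0.32 log units; beyond the scatter), was modest. Compound 3 is therefore expected to stay near compound 2, with a small move in either direction possible; the estimated step is a 1.7-fold higher number from compound 2 to compound 3 (0.22 log units; within the scatter). For compound 3 the estimated value in this assay is 20 nM, within a range from 5 nM to 80 nM.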

Compound 3, half-maximal effective concentration: 4.3 nM
Compound 3: middle estimate off by 4.7-fold (0.67 log units), on the high side; the whole stated range lies above it.
By their numbers in this assay, from the lowest: compound 3; then compound 2; then compound 1.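

The place on the aromatic carbon, para to a large group, is not limited to five-membered rings. In this assay, pyridin-3-yl in place of 1H-1,2,4-triazol-1-yl gives a 2.8-fold lower number from compound 2 to compound 3 (0.45 log units; beyond the scatter), so a six-membered aromatic ring with 1 hetero atom is accepted here and gives the lowest number of the three compounds, while the same ring in place of 2H-tetrazol-2-yl gives a 5.8-fold lower number from compound 1 to compound 3 (0.76 log units; beyond the scatter), the widest step in this small set. No outside information is available to explain why this change lowers the number.

The swap from compound 2 to compound 3 changes ring size and the number of hetero atoms together, so these compounds cannot show which of the two changes matters, or whether the ring nitrogen matters at all. A plain phenyl ring or a pyridin-4-yl group at this place would help separate those questions, and a ring bearing an amine or a carboxylic acid would show how far the place accepts other kinds of group.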